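A few compounds are considered here, and "the series" means these few. Any claim that something is new, unique, unknown or untested is made for them only; others in the source may bear on it.

In an assay on isolated protein with Bile acid receptor (Homo sapiens) as the target (a lower number here means that less compound is needed, a higher number that more compound is needed for the effect), compound 2 `COC(=O)/C=C/c1cccc(N(Cc2ccc(/C=C/c3ccc(F)cc3)cc2)C(=O)NC(C)C)c1` gives 348 nM, the highest of the three numbers shown, beyond the scatter only against compound 1 `COC(=O)/C=C/c1cccc(N(Cc2ccc(/C=C/c3ccc(F)cc3)cc2)C(=O)C(C)C)c1`, which gives 120 nM, while compound 3 `COC(=O)/C=C/c1cccc(N(Cc2ccc(/C=C/c3ccc(F)cc3)cc2)C(=O)C2CCCCC2)c1` gives 185 nM. Every measured step alters the group on the carbonyl carbon: a 2.9-fold higher number from compound 1 to compound 2 (0.46 log units; beyond the scatter), a 1.5-fold higher number from compound 1 to compound 3 (0.19 log units; within the scatter) and a 1.9-fold lower number from compound 2 to compound 3 (0.27 log units; within the scatter). Compound 4 `COC(=O)/C=C/c1cccc(N(Cc2ccc(-c3cccc(Cl)c3)cc2)C(=O)NC(C)C)c1` differs from compound 2 elsewhere: 3-chlorophenyl in place of 2-(4-fluorophenyl)ethenyl on an aromatic carbon. Within the data shown here, no measured step touches this part of the shared core, so the data give no direct guide to the size or direction of the coming step. Compound 4 is therefore estimated at 600 nM, with a range from 150 nM to 2500 nM. That estimate amounts to an expected 1.7-fold higher number from compound 2 to compound 4 (0.24 log units; within the scatter), offered with little confidence.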

Compound 4, half-maximal effective concentration: 1400 nM
For compound 4 the middle estimate is 2.3-fold (0.37 log units) below the measured one, and the stated range covers the measured number.
By their numbers in this assay, from the lowest: compounds 1, 3 and 2 (each within the scatter of the next, the first and the last beyond it); then compound 4.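

In this assay, among these compounds, the position para to a large group proves responsive: 3-chlorophenyl in place of 2-(4-fluorophenyl)ethenyl gives a 4.0-fold higher number from compound 2 to compound 4 (0.60 log units; beyond the scatter), whereas the earlier compounds varied only the group on the carbonyl carbon. This single step removes the double bond outside aromatic rings and exchanges fluorine for chlorine, and it does not separate these changes. Nothing available explains the step. Still open, on these data alone, is how a 4-fluorophenyl or a 2-(4-fluorophenyl)ethyl group would behave here. As far as these compounds go, it is also open whether 3-chlorophenyl would shift the number similarly with isopropyl on the carbonyl carbon.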